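This account rests on a few compounds, and the source may have more. Where it says the series, first, only, none or still open, it means among the compounds named here.

In a functional assay on HeLa cells (Homo sapiens) for antiproliferative activity, read by MTT assay, with a stated time of 72 h (on this read-out lower numbers stand for stronger inhibition and higher numbers for weaker inhibition), compound 1 (`O=C1COc2ccc(-c3cnc(Cl)c(NS(=O)(=O)c4ccc(F)cc4)c3)cc2N1C1CCCCC1`) gives 14300 nM and compound 2 (`COc1ncc(-c2ccc3c(c2)N(c2ccccc2)C(=O)CO3)cc1NS(=O)(=O)c1ccc(F)cc1`) gives 1530 nM. Compound 3 (`O=C1COc2ccc(-c3cnc(Cl)c(NS(=O)(=O)c4ccc(F)cc4)c3)cc2N1c1ccc(Cl)cc1`) reads > 40000 nM, which is a limit of the assay and not a number. The series holds (the limit of > 40000 nM in this assay, at which 1 of the 3 values shown sits). Compound 4 (`O=C1COc2ccc(-c3cnc(Cl)c(NS(=O)(=O)c4ccc(F)cc4)c3)cc2N1c1ccccc1`) arises by hydrogen in place of chloro on an aromatic carbon. The nearest measured step is an at least 2.7-fold higher number from compound 1 to compound 3 (0.44 log units; beyond the scatter), with 4-chlorophenyl in place of cyclohexyl; it does not isolate the chloro. A lower number is therefore expected in this assay, of uncertain size. The expected step is an at least 2.8-fold lower number from compound 3 to compound 4 (0.45 log units; beyond the scatter). For compound 4 the estimate is 14000 nM, with an expected range of 4000 nM to 40000 nM.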

Compound 4, half-maximal inhibitory concentration: 10300 nM
Beside the measured number, compound 4's estimate is 1.4-fold (0.13 log units) above it, and the stated range covers the measured number.
By their numbers in this assay, from the lowest: compound 2; then compounds 4 and 1 (each within the scatter of the next). At a limit, above all of these: compound 3.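

In this assay, the chloro on the 4-chlorophenyl group, para to a large group, is now tested on its own, and hydrogen in its place gives an at least 3.8-fold lower number from compound 3 to compound 4 (0.58 log units; beyond the scatter) on this single change. Compound 3 stands at a limit of the assay, so that step has no fixed size: the limit of > 40000 nM in this assay, at which 1 of the 4 values shown sits. Phenyl and cyclohexyl on the amide-type nitrogen are not told apart, with a 1.4-fold lower number from compound 1 to compound 4 (0.14 log units; within the scatter) in that comparison, while a 6.7-fold higher number from compound 2 to compound 4 (0.83 log units; beyond the scatter) isolates chloro in place of methoxy on the other aromatic carbon.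

Open, as far as these compounds go, is how an amine or a carboxylic acid would read at the para place on the phenyl group. Also open, from the compounds shown here alone, is whether the methoxy step holds with cyclohexyl on that nitrogen.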